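This account rests on a few compounds, and the source may have more. Where it says the series, first, only, none or still open, it means among the compounds named here.

Notes on the series.

Compound 1 `O=c1c(-c2cccc(Br)c2)nc2ccccc2n1Cc1ccccc1` and compound 2 `COC(=O)c1ccc(N)c(-c2nc3ccccc3n(Cc3ccccc3)c2=O)c1` share the core with a larger substituent on the carbon bound to the aromatic nitrogen. In an assay on cells for activation of Cystic fibrosis transmembrane conductance regulator (Homo sapiens), read by fluorescence, with a stated time of 10 min (on this read-out higher numbers stand for an effect only at larger amounts of compound and lower numbers for an effect already at smaller amounts), compound 1 gives 330 nM. In this assay compound 2 gives 550 nM. The two values lie within the usual scatter of each other.

Compound 3 `Cn1c(=O)c(-c2cccc([N+](=O)[O-])c2)nc2ccccc21` carries only a methyl on that nitrogen. For compound 3 this assay reports no number but a limit, > 10000 nM. This is the one case of the limit of > 10000 nM in this assay, at which 1 of the 3 values shown sits, among the three values shown, so where compound 3 truly stands is open; it is only known to sit at the weak end of the measured set.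

Compound 4 `O=c1c(-c2cccc([N+](=O)[O-])c2)nc2ccccc2n1Cc1ccco1` is not yet measured. It differs from compound 3 by furan-2-yl in place of hydrogen on a saturated chain carbon bound to an aromatic nitrogen. Within the data shown here, no measured pair shows exactly this change, so its size is not known from the data. Compound 1 and compound 2, each with a larger group on that carbon, give numbers well within range, which suggests that a larger group there can be tolerated. The step from compound 3 to compound 4 is expected to run toward lower numbers, estimated at an at least 6.6-fold lower number from compound 3 to compound 4 (0.82 log units; beyond the scatter). Compound 4 is expected to give about 1500 nM, with a range from 300 nM to 8000 nM.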

Compound 4, half-maximal effective concentration: 20 nM
For compound 4 the middle estimate is 75-fold (1.88 log units) above the measured one; the whole stated range lies above it.
By their numbers in this assay, from the lowest: compound 4; then compounds 1 and 2 (each within the scatter of the next). At a limit, above all of these: compound 3.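

Notes on the result.

In this assay, among these compounds, furan-2-yl in place of hydrogen on a saturated chain carbon bound to an aromatic nitrogen gives an at least 500-fold lower number from compound 3 to compound 4 (2.69 log units; beyond the scatter), the first step that can be read with only this one place changed. Among the compounds shown here, compound 1 and compound 2 differ from compound 3 in more than one place, so they showed only that a larger group there goes with a measured value, whereas this pair ties the move away from the limit to the change from methyl to (furan-2-yl)methyl alone. Compound 3 stands at a limit, and the step carries that limit with it, so its full size stays open: the limit of > 10000 nM in this assay, at which 1 of the 4 values shown sits.

The compounds shown leave open whether the step belongs to furan-2-yl in particular or to any ring on that carbon; phenyl, thiophen-2-yl or a longer alkyl chain in the same place, each with the rest of compound 4 unchanged, would bear on this. Also open, as far as these compounds go, is whether the same change gives a step of similar size on a compound carrying the bromine of compound 1.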